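Swapping Trifluoromethyl for a Larger Fluorinated Group

This account rests on a few compounds, and the source may have more. Where it says the series, first, only, none or still open, it means among the compounds named here.

Of the compounds shown here, three sharing one core have been measured in an ADME assay on a cell-free system (plasma, Homo sapiens) for protein binding. Among the compounds with values here, compound 1 `CCOc1nc2nc(C)cc(Nc3ccc(S(F)(F)(F)(F)F)cc3)n2n1` gives 97.7% and compound 2 `Cc1cc(Nc2ccc(S(F)(F)(F)(F)F)cc2)n2nc(C(C)(F)F)nc2n1` gives 97.4%; the only single-point step among them, a 1.1-fold higher unbound fraction from compound 1 to compound 2 (0.05 log units; within the scatter), stays within the scatter. Compound 3 `CSc1nc2nc(C)cc(Nc3ccc(C(F)(F)F)cc3)n2n1` gives 91.8%, the highest unbound fraction of the three, beyond the scatter from both others. Compound 4 `CSc1nc2nc(C)cc(Nc3ccc(S(F)(F)(F)(F)F)cc3)n2n1` differs from compound 3 by a group of 6 heavy atoms (5 fluorine, 1 sulfur; no ring) in place of a group of 4 heavy atoms (1 carbon, 3 fluorine; no ring), on an aromatic carbon. Within the data shown here, no measured step covers this exact change. Among the measured compounds shown here, still, the entering group is the one carried by compound 1 at 97.7% and by compound 2 at 97.4%. Compound 4 is therefore expected to shift toward stronger binding, a step of a 2.3-fold lower unbound fraction from compound 3 to compound 4 (0.37 log units; beyond the scatter). Compound 4 is estimated at 96.5%, within 93.5% to 98.5%.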

Compound 4, plasma protein binding: 97.7%
Estimate against measurement, compound 4: 1.5-fold (0.18 log units) (unbound fraction) above; the measured number falls inside the stated range.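

In this assay, the direct swap of trifluoromethyl for the group of 6 heavy atoms (5 fluorine, 1 sulfur), para to a large group, now has a measured size (a 3.6-fold lower unbound fraction from compound 3 to compound 4 (0.55 log units; beyond the scatter)). With that group held fixed, methylsulfanyl on the other side of the core reads much like its neighbours (a 1.1-fold lower unbound fraction from compound 2 to compound 4 (0.05 log units; within the scatter); no change at the digits printed from compound 1 to compound 4 (within the scatter)). Nothing available explains the shift in binding.

On these data alone, whether the same step holds with ethoxy or 1,1-difluoroethyl on the core remains open. So does how a chlorine atom, an amine or a carboxylic acid would behave at this position.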